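From a selenium group to 2-aminoethoxy

The compounds below may be only part of what the source reports. "The series", "measured", "known", "first", "only" and "open" are said of these compounds alone.

In a functional assay on RKO cells (Homo sapiens) for inhibition, read by MTT assay, with a stated time of 48 h (a lower number here means a stronger inhibitor, a higher number a weaker inhibitor), compound 1 `COc1ccc(N(C)c2nc(C)nc3ccccc23)cc1OCCCC[Se]C#N` gives 1360 nM while compound 2 `COc1ccc(N(C)c2nc(C)nc3ccccc23)cc1C[Se]C#N` gives 316 nM as the lower of the two numbers. Within the data shown here, the one measured step, modest in size, is a 4.3-fold lower number from compound 1 to compound 2 (0.63 log units; beyond the scatter) and it keeps selenium on both sides. Compound 3 `COc1ccc(N(C)c2nc(C)nc3ccccc23)cc1OCCN` differs from compound 2 by a group of 4 heavy atoms (2 carbon, 1 nitrogen, 1 oxygen; no ring) in place of a group of 4 heavy atoms (2 carbon, 1 nitrogen, 1 selenium; no ring), on an aromatic carbon with the entering group being 2-aminoethoxy, ortho to a methoxy group and meta to a large group. Among the measured compounds shown here, no measured step removes selenium, so the earlier step is only a loose guide to size. With no other guide, a modest rise of similar size is expected in this assay and not a further fall. The estimated change is a 2.5-fold higher number from compound 2 to compound 3 (0.40 log units; beyond the scatter) on this expectation. Compound 3 is estimated at 800 nM with 150 nM to 4000 nM as the expected range.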

Compound 3, half-maximal inhibitory concentration: 343 nM
Compound 3: the middle estimate sits 2.3-fold (0.37 log units) above what was measured, within the range that was stated.
By their numbers in this assay, from the lowest: compounds 2 and 3 (each within the scatter of the next); then compound 1.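

In this assay, 2-aminoethoxy in place of the selenium-bearing group on this aromatic carbon, ortho to a methoxy group, gives a 1.1-fold higher number from compound 2 to compound 3 (0.04 log units; within the scatter), so among these compounds selenium is not required for a number at this level. The second step, a 4.0-fold lower number from compound 1 to compound 3 (0.60 log units; beyond the scatter), shows that a compound without selenium can also stand clearly apart from a selenium compound, so the presence of selenium alone does not set the number across this set. No supporting measurement is available to explain either step.

From the compounds shown here alone, it remains open whether the amine at the end of the chain matters, as against a hydroxyl group or a plain ethoxy group on this carbon. Also open, going by these compounds, is how a longer chain ending in an amine would compare with compound 1.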